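A few compounds are considered here, and "the series" means these few. Any claim that something is new, unique, unknown or untested is made for them only; others in the source may bear on it.

Compound 1, `O=c1[nH]cc(S(=O)(=O)Nc2ccccc2-c2cn(-c3ccccc3)nn2)c(=O)[nH]1`: 6160 nM
Compound 2, `O=c1[nH]cc(S(=O)(=O)Nc2cccc(-c3cn(-c4ccccc4Cl)nn3)c2)c(=O)[nH]1`: 4030 nM
Compound 3, `Cc1ccccc1-n1cc(-c2ccc(NS(=O)(=O)c3c[nH]c(=O)[nH]c3=O)cc2)nn1`: 14500 nM

All three compounds were tested in a functional assay on HepG2 cells (Homo sapiens) for antiproliferative activity, read by MTT assay, with a stated time of 24 h; on this read-out lower numbers stand for stronger inhibition and higher numbers for weaker inhibition. On these numbers compound 3 stands highest, and therefore weakest: its gap to compound 1, the nearest of the other two, lies beyond the usual scatter, and its gap to compound 2, the furthest, lies beyond it as well. The three compounds differ from one another in more than one place, so no single change can be read off among them.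

Compound 4, `Cc1ccc(-n2cc(-c3ccc(NS(=O)(=O)c4c[nH]c(=O)[nH]c4=O)cc3)nn2)cc1`, has not yet been measured. It differs from compound 3 in one respect: 4-methylphenyl in place of 2-methylphenyl on an aromatic nitrogen. Among the compounds with values here, since no pair of measured compounds isolates a move of this kind, the size of the step is not charted by the data. The expected step of a 1.3-fold lower number from compound 3 to compound 4 (0.12 log units; within the scatter) is small, toward a somewhat lower number, and probably not beyond the scatter. Compound 4 is estimated at 11000 nM, with a range from 4000 nM to 30000 nM.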

Compound 4, half-maximal inhibitory concentration: 11600 nM
Estimate against measurement, compound 4: 1.1-fold (0.02 log units) below; the measured number falls inside the stated range.
By their numbers in this assay, from the lowest: compounds 2, 1, 4 and 3 (each within the scatter of the next, the first and the last beyond it).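

With 4-methylphenyl in place of 2-methylphenyl on the aromatic nitrogen, the reading in this assay is a 1.3-fold lower number from compound 3 to compound 4 (0.10 log units; within the scatter), and this step lies within the usual scatter. This is the first pair among the compounds shown that differs in one place, and it shows that these two placements of the methyl group on the phenyl ring cannot be told apart on this read-out. The data shown offer no measured basis for explaining this result.

As far as these compounds go, whether a different group on this phenyl ring, such as a methoxy group, an amine or a carboxylic acid, would give a step beyond the scatter remains open. From the compounds shown here alone, compound 1 and compound 2 differ from this pair in more than one place, so how the same swap would read on their cores is also open.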